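Amine variation on the shared core: toward compound 4

This account rests on a few compounds, and the source may have more. Where it says the series, first, only, none or still open, it means among the compounds named here.

Measured so far:
compound 1 `CCC(CC)Nc1nc(C)nc2c(-c3c(C)cc(N(C)C)nc3C)c(C)nn12`: 25.6 nM
compound 2 `CCN(CC)c1nc(C)nc2c(-c3c(C)cc(N(C)C)nc3C)c(C)nn12`: 58 nM
compound 3 `CCCCN(CC)c1nc(C)nc2c(-c3c(C)cc(N(C)C)nc3C)c(C)nn12`: 32.8 nM

In an assay on cell membranes for displacement of a labelled ligand from corticotropin-releasing factor receptor 1 (Rattus norvegicus) (a higher number here means a weaker inhibitor, a lower number a stronger inhibitor), compound 3 gives 32.8 nM, the second highest of the three numbers; compound 1 sits a 1.3-fold higher number from compound 1 to compound 3 (0.11 log units; within the scatter) away, compound 2 a 1.8-fold lower number from compound 2 to compound 3 (0.25 log units; within the scatter) away, both within the scatter. The step to compound 4 `COCCNc1nc(C)nc2c(-c3c(C)cc(N(C)C)nc3C)c(C)nn12` is (2-methoxyethyl)amino in place of butyl(ethyl)amino on an aromatic carbon.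

For the measured compounds named here, two measured steps bear on it. Going by the values given here, the one change that left the scatter, a 2.3-fold higher number from compound 1 to compound 2 (0.36 log units; beyond the scatter), replaced a group carrying a hydrogen on its nitrogen by one without. Within the scatter, a 1.3-fold higher number from compound 1 to compound 3 (0.11 log units; within the scatter) and a 1.8-fold lower number from compound 2 to compound 3 (0.25 log units; within the scatter) show that the size of the alkyl chains hardly moved this assay. Among the compounds with values here, the entering (2-methoxyethyl)amino group again carries a hydrogen on its nitrogen, as in compound 1, but it is shorter and brings an oxygen, for which no measured step exists. For compound 4 the expected step is therefore a 1.2-fold higher number from compound 3 to compound 4 (0.09 log units; within the scatter), a shift of no more than the scatter in either direction. Compound 4 is estimated at 40 nM, with a range from 14 nM to 130 nM.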

Compound 4, half-maximal inhibitory concentration: > 10000 nM
Compound 4 was reported as a limit; the forecaster's own chance of this, stated with the estimate: 3%; at least 250-fold (2.39 log units) between middle value and limit.
By their numbers in this assay, from the lowest: compounds 1, 3 and 2 (each within the scatter of the next, the first and the last beyond it). At a limit, above all of these: compound 4.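

Compound 4 stands at a limit in this assay, not at a number: the limit of > 10000 nM in this assay, at which 1 of the 4 values shown sits. With a hydrogen on the nitrogen in both partners, an at least 390-fold higher number from compound 1 to compound 4 (2.59 log units; beyond the scatter) shows that this hydrogen does not by itself keep the binding seen with pentan-3-yl; here the group on that nitrogen decides the outcome. Against the tertiary amines, an at least 300-fold higher number from compound 3 to compound 4 (2.48 log units; beyond the scatter) and an at least 170-fold higher number from compound 2 to compound 4 (2.23 log units; beyond the scatter) are much larger than any step among the first three compounds, so this aromatic carbon, opposite the ring nitrogen, is far more sensitive to the amine than those compounds suggested.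

Compound 4 brings a shorter group and an oxygen together, so the compounds shown leave open which of the two goes with the loss. A butylamino group would keep a chain without the oxygen, and a (3-methoxypropyl)amino group would place the oxygen on a longer chain.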